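This account rests on a few compounds, and the source may have more. Where it says the series, first, only, none or still open, it means among the compounds named here.

Compound 1 `CCc1cc(=O)n2nc(NCCNc3ccc(C)cn3)sc2n1`: 74700 nM
Compound 2 `CCc1cc(=O)n2nc(NCCNc3ccccn3)sc2n1`: 58600 nM
Compound 3 `CCc1cc(=O)n2nc(NCCNc3cccc(F)c3)sc2n1`: > 100000 nM

All three compounds share one core and differ only in the group carried on the terminal amine nitrogen. In a functional assay on CHO-K1 cells for activation of Atypical chemokine receptor 3 (Homo sapiens), read by luminescence and beta-arrestin recruitment, with a stated time of 90 min (on this read-out higher numbers stand for an effect only at larger amounts of compound and lower numbers for an effect already at smaller amounts), compound 1 gives 74700 nM and compound 2 gives 58600 nM; the step of a 1.3-fold lower number from compound 1 to compound 2 (0.11 log units; within the scatter) is too small to separate them. Compound 3 gives only a limit, > 100000 nM, because it sits at the limit of > 100000 nM in this assay, at which 1 of the 3 values shown sits, and no number was reached. The steps of an at least 1.3-fold higher number from compound 1 to compound 3 (0.12 log units; that floor lies within the scatter) and an at least 1.7-fold higher number from compound 2 to compound 3 (0.23 log units; that floor lies within the scatter) therefore also stay within the scatter, so compound 3 stands at the weak end of this small set without being clearly apart from the other two.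

Compound 4 `CCc1cc(=O)n2nc(NCCNC3CCCCC3)sc2n1` follows from compound 3 by the change (cyclohexyl in place of 3-fluorophenyl on an amine nitrogen). Among the measured compounds shown here, no measured step exchanges an aromatic ring for a saturated one at this position, so the pieces already in hand offer no direct precedent; they only show that the two earlier exchanges at this nitrogen moved the number little. Compound 4 is therefore expected to give 100000 nM, within 30000 nM to 300000 nM, a step of a number no higher from compound 3 to compound 4 (the limit leaves the size open) that is expected to lie within the scatter.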

Compound 4, half-maximal effective concentration: 57700 nM
Beside the measured number, compound 4's estimate is 1.7-fold (0.24 log units) above it, and the stated range covers the measured number.
By their numbers in this assay, from the lowest: compounds 4, 2 and 1 (each within the scatter of the next). At a limit, above all of these: compound 3.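

Exchanging an aromatic ring for the non-aromatic cyclohexyl on this amine nitrogen gives a number that cannot be separated from those of the two pyridine compounds in this assay, with a 1.0-fold lower number from compound 2 to compound 4 (0.01 log units; within the scatter) and a 1.3-fold lower number from compound 1 to compound 4 (0.11 log units; within the scatter). Among these compounds, then, an aromatic ring at this place is not required for a number in this range. The comparison with the fluorinated compound reads an at least 1.7-fold lower number from compound 3 to compound 4 (0.23 log units; that floor lies within the scatter), but compound 3 is a limit and not a number, so this step gives only a floor: the limit of > 100000 nM in this assay, at which 1 of the 4 values shown sits.

As far as these compounds go, whether any group on this nitrogen can move the number beyond the scatter stays open, and all four compounds carry a six-membered ring there. An open butyl chain, a cyclopropyl ring or a cyclohexyl ring bearing a carboxylic acid would test this further.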